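Replacing 4-isopropylpiperazin-1-yl with chloro in an antiproliferative series

The source may report more compounds than this note shows. Statements on the series, on what has been measured and on what is new or still open speak of the compounds shown alone.

In a functional assay on PC-3 cells (Homo sapiens) for antiproliferative activity, read by MTT assay, with a stated time of 96 h (a higher number here means a weaker inhibitor, a lower number a stronger inhibitor), compound 1 `CCN1CCN(c2ccc3nnnc(Nc4cccc(OC(F)(F)F)c4)c3n2)CC1` gives 16900 nM, and compound 2 `CC(C)N1CCN(c2ccc3nnnc(Nc4cccc(OC(F)(F)F)c4)c3n2)CC1` gives 13800 nM. Compound 2 therefore has a single measured neighbour, and the two cannot be told apart. Compound 3 `FC(F)(F)Oc1cccc(Nc2nnnc3ccc(Cl)nc23)c1` carries chloro in place of 4-isopropylpiperazin-1-yl on an aromatic carbon, next to the ring nitrogen: chloro in place of 4-isopropylpiperazin-1-yl on an aromatic carbon. For the measured compounds named here, only one measured step is available, a 1.2-fold lower number from compound 1 to compound 2 (0.09 log units; within the scatter), and it alters just the end of the group that compound 3 loses. Going by the values given here, it bears only weakly on removing that whole group, and no measured compound lacks it. The expectation in this assay is thus no clear step in either direction, held with wide uncertainty. The estimated change is a 1.2-fold lower number from compound 2 to compound 3 (0.06 log units; within the scatter). For compound 3 the expected value is 12000 nM, with an estimated range of 3000 nM to 50000 nM.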

Compound 3, half-maximal inhibitory concentration: 5990 nM
Beside the measured number, compound 3's estimate is 2.0-fold (0.30 log units) above it; low and high end bracket the measured number.
By their numbers in this assay, from the lowest: compound 3; then compounds 2 and 1 (each within the scatter of the next).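

In this assay, the whole piperazine-bearing group proves dispensable at this aromatic carbon: chloro in place of 4-isopropylpiperazin-1-yl gives a 2.3-fold lower number from compound 2 to compound 3 (0.36 log units; beyond the scatter), and chloro in place of 4-ethylpiperazin-1-yl gives a 2.8-fold lower number from compound 1 to compound 3 (0.45 log units; beyond the scatter), both modest steps. Compound 1 and compound 2 differ only at the end of that group and could not be told apart, so these are the only steps shown at this position that lie beyond the scatter. Nothing measured here accounts for the size or direction of these steps.

Going by these compounds, it remains open whether the lower number comes from chloro itself or simply from losing the ring. A hydrogen, a methoxy or a dimethylamino group on this carbon would separate those two readings.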